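The compounds below may be only part of what the source reports. "The series", "measured", "known", "first", "only" and "open" are said of these compounds alone.

Three compounds sharing one core have been measured in a functional assay, tested at 400 ug/mL; on this read-out lower numbers stand for a weaker effect and higher numbers for a stronger effect at the one concentration tested:

Compound 1 `COc1cc(Br)c(C2C(C#N)=C(N)OC(c3c[nH]c4ccccc34)=C2C#N)cc1OC`: 26.7%
Compound 2 `Cc1ccccc1C1C(C#N)=C(N)OC(c2c[nH]c3ccccc23)=C1C#N`: 25.7%
Compound 3 `Cc1ccc(C2C(C#N)=C(N)OC(c3c[nH]c4ccccc34)=C2C#N)cc1`: 8.5%

Compound 2 stands second highest of these three numbers. Its nearest neighbour is compound 1, whose value lies within the scatter of compound 2, so no order between these two can be claimed. Compound 3 lies furthest away, with a step of a number 17.2 percentage points lower from compound 2 to compound 3 (beyond the scatter), which is beyond the scatter.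

The next compound, compound 4 `N#CC1=C(N)OC(c2c[nH]c3ccccc23)=C(C#N)C1c1cccc2ccccc12`, changes the same position of compound 2 that was changed in compound 3: naphthalen-1-yl in place of 2-methylphenyl on a saturated ring carbon.

Within the data shown here, only one measured step bears on this position, the step of a number 17.2 percentage points lower from compound 2 to compound 3 (beyond the scatter), and it describes a different replacement of the 2-methylphenyl group. It shows that this position can shift the read-out by a modest amount, but it does not show in which direction a naphthalen-1-yl group would move it. Among the measured compounds shown here, a modest step either way, or none beyond the scatter, is therefore the reasonable expectation for this assay, and the estimate leans slightly lower in line with the one change seen so far.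

For compound 4 the expected value is 20%, with a range from 8% to 34%. This estimate means an expected step of a number 5.7 percentage points lower from compound 2 to compound 4 (within the scatter).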

Compound 4, a percentage reported as activity, at one concentration (the size of the read-out at that concentration, not a potency): 10.4%
For compound 4 the middle estimate is 9.6 percentage points above the measured one; measured number inside the range.
By their numbers in this assay, from the lowest: compounds 3 and 4 (each within the scatter of the next); then compounds 2 and 1 (each within the scatter of the next).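

In this assay, naphthalen-1-yl on the saturated ring carbon gives a number 15.3 percentage points lower from compound 2 to compound 4 (beyond the scatter), so a second, different replacement of the 2-methylphenyl group also gives a lower number. Among compounds 2, 3 and 4, the 2-methylphenyl group therefore stands apart from both replacements, while those two replacements cannot be separated, with a number 1.9 percentage points higher from compound 3 to compound 4 (within the scatter), even though naphthalen-1-yl brings a second six-membered aromatic ring and 4-methylphenyl does not. No measured information is available to explain these steps.

The compounds shown leave open whether a group with no aromatic ring, such as cyclohexyl, or a phenyl ring carrying an amine or a carboxylic acid, would stay level with compound 2 or also give a lower number. Each number also comes from a single concentration, so how these compounds would compare in potency remains an open question.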